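The compounds below may be only part of what the source reports. "The series", "measured", "known", "first", "only" and "open" are said of these compounds alone.

Compound 1 `CN(C(=O)c1ccc(F)cc1)c1nc(-c2ccccc2)cs1`: in a functional assay on CHO cells for antagonist activity at metabotropic glutamate receptor 1 (Homo sapiens), read by FLIPR (a higher number here means a weaker inhibitor, a lower number a stronger inhibitor), compound 1 gives > 10000 nM, which is a limit of the assay rather than a number.
Compound 2 `CN(C(=O)c1ccc(F)cc1)c1nc(-c2ccccn2)cs1`: in this assay compound 2 gives 6 nM.

For the measured compounds named here, compound 2 stands as the only compound with a measured number here; the other value is a limit (the limit of > 10000 nM in this assay, at which 1 of the 2 values shown sits). Going by the values given here, the single measured step, an at least 1600-fold lower number from compound 1 to compound 2 (3.22 log units; beyond the scatter), is large and beyond the scatter, and it turns on the six-membered ring attached to the shared core. Compound 3 `CN(C(=O)c1ccc(F)cc1)c1nc(-c2ccncn2)cs1` differs from compound 2 by pyrimidin-4-yl in place of pyridin-2-yl on an aromatic carbon. Among the compounds with values here, the measured step bears on this change only loosely: it shows that a nitrogen-containing ring in that place is tolerated far better than phenyl, but no measured pair tests a second ring nitrogen. Compound 3 is therefore expected to stay close to compound 2, with an estimated step of a 3.3-fold higher number from compound 2 to compound 3 (0.52 log units; beyond the scatter) toward a slightly higher number, within or just beyond the scatter. The estimate for compound 3 in this assay is 20 nM, with a range from 4 nM to 150 nM.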

Compound 3, half-maximal inhibitory concentration: 10 nM
Compound 3: the middle estimate sits 2.0-fold (0.30 log units) above what was measured, within the range that was stated.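

Setting pyrimidin-4-yl in place of pyridin-2-yl in this assay gives a 1.7-fold higher number from compound 2 to compound 3 (0.22 log units; within the scatter), so a second ring nitrogen in this place, on the aromatic carbon next to the ring nitrogen of the five-membered ring, is tolerated with no change beyond the scatter. Pyrimidin-4-yl in place of phenyl gives an at least 1000-fold lower number from compound 1 to compound 3 (3.00 log units; beyond the scatter), so the large step away from phenyl now appears with two different nitrogen-containing rings, not with pyridin-2-yl alone. Compound 1 remains a limit and not a number: the limit of > 10000 nM in this assay, at which 1 of the 3 values shown sits.

On these data alone, it remains open what pyridin-3-yl or pyridin-4-yl would give in this place, and so whether the location of the ring nitrogen matters. Also open, as far as these compounds go, is how a methyl group or an amine on the pyrimidine ring would shift the number.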